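The compounds below may be only part of what the source reports. "The series", "measured", "known", "first", "only" and "open" are said of these compounds alone.

Measured so far:
Compound 1, `O=C(Nc1nc(-c2ccccc2)cn2cc(-c3ccccc3)nc12)c1ccc(Cl)cc1`: 1%
Compound 2, `O=C(Nc1nc(-c2ccccc2)cn2cc(-c3ccccc3)nc12)c1ccco1`: 10%

Going by the values given here, in an assay on cells for displacement of a labelled ligand from adenosine receptor A1 (Homo sapiens), read by scintillation counting, with a stated time of 120 min, tested at 1 uM (on this read-out higher numbers stand for more inhibition at the one concentration tested (going by the name of the read-out) and lower numbers for less inhibition), compound 2 gives 10%, and the only other measured compound, compound 1, gives 1%. Among the compounds with values here, the one measured step, a number 9 percentage points higher from compound 1 to compound 2 (within the scatter), lies within the scatter, so the two numbers cannot be told apart; both are small readings.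

Compound 3, `O=C(Nc1nc(-c2ccccc2)cn2cc(-c3ccccc3)nc12)c1cccnc1`, differs from compound 2 by pyridin-3-yl in place of furan-2-yl on a carbonyl carbon. The step that bears on it is the step on the same carbonyl carbon, from compound 1 to compound 2, which was within the scatter. Within the data shown here, with that as the only guide, a change at this position is expected to move the reading by no more than the scatter, in no particular direction. Compound 3 is therefore expected to give about 8%, in the range -5% to 25%. The expected step is a number 2 percentage points lower from compound 2 to compound 3 (within the scatter).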

Compound 3, a percentage reported as inhibition, at one concentration (the size of the read-out at that concentration, not a potency): 11%
Compound 3: the middle estimate sits 3 percentage points below what was measured, and the stated range covers the measured number.
By their numbers in this assay, from the lowest: compounds 1, 2 and 3 (each within the scatter of the next).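

In this assay pyridin-3-yl in place of furan-2-yl on the carbonyl carbon gives a number 1 percentage points higher from compound 2 to compound 3 (within the scatter) and pyridin-3-yl in place of 4-chlorophenyl gives a number 10 percentage points higher from compound 1 to compound 3 (within the scatter) so all three compounds now stand within the scatter of one another. This position has thus carried a five-membered and two six-membered aromatic rings, with and without a ring hetero atom, and every reading remains small. Exchanging the five-membered aromatic ring for the six-membered one, each with one hetero atom, shows no readable effect at the one concentration tested.

Nothing available accounts for these readings. Still open, from the compounds shown here alone, is whether a non-aromatic group on this carbonyl carbon, such as a longer alkyl chain or one ending in an amine or a carboxylic acid, would give a reading beyond the scatter.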